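Replacing Phenyl with Pyridin-3-yl in Compound 4

The source may report more compounds than this note shows. Statements on the series, on what has been measured and on what is new or still open speak of the compounds shown alone.

Measured so far:
Compound 1 `CCOC(=O)C1=C(Nc2ccccc2)S/C(=C\c2ccccc2)C1=O`: 29.6%
Compound 3 `CCOC(=O)C1=C(Nc2cccc(C(F)(F)F)c2)S/C(=C\c2ccc[nH]2)C1=O`: 22.8%
Compound 2 `CCOC(=O)C1=C(Nc2cccc(F)c2)S/C(=C\c2ccc[nH]2)C1=O`: a limit of the assay, < 10%

In a functional assay on A549 cells (Homo sapiens) for inhibition, read by MTT assay, with a stated time of 72 h, tested at 10 uM (a higher number here means more inhibition at the concentration tested (going by the name of the read-out), a lower number less inhibition), compound 1 gives 29.6%. This is the highest of the two numbers shown, but compound 3 sits within the usual scatter of it, so no order between the two can be claimed. The value of compound 2 is a limit rather than a number, as noted in the limit of < 10% in this assay, at which 1 of the 3 values shown sits.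

The new compound is compound 4 `CCOC(=O)C1=C(Nc2ccccc2)S/C(=C\c2cccnc2)C1=O`. Its change from compound 1 is pyridin-3-yl in place of phenyl on a double-bonded chain carbon bound to a double-bonded ring carbon.

Going by the values given here, only one measured step exists, a number at least 12.8 percentage points higher from compound 2 to compound 3 (beyond the scatter), and it concerns a different part of the structure, the ring attached to the amine, not the place changed here. Among the compounds with values here, no measured step therefore bears directly on the change from compound 1 to compound 4, and the two rings exchanged are of the same size. With nothing pointing one way or the other, a step in this assay that stays within the scatter is expected. Compound 4 is therefore expected to give about 25%, in a range from 10% to 40%. That estimate means a step of a number 4.6 percentage points lower from compound 1 to compound 4 (within the scatter), expected to remain within the scatter.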

Compound 4, a percentage reported as inhibition, at one concentration (the size of the read-out at that concentration, not a potency): < 10%
Compound 4: a limit, no number; the forecaster's own chance of this, stated with the estimate: 20%; at least 15 percentage points between middle value and limit.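

Going by these compounds alone, until this result, the only measured step concerned the ring on the amine, so the group on the double-bonded chain carbon bound to a double-bonded ring carbon had not been tested on its own. In this assay, pyridin-3-yl in place of phenyl at this place gives a number at least 19.6 percentage points lower from compound 1 to compound 4 (beyond the scatter), which shows that the read-out depends on this group: the two rings have the same number of heavy atoms, and one ring carbon is exchanged for a nitrogen that counts as a hydrogen-bond acceptor. The value of compound 4 is a limit of the assay and not a number, so the step gives only a minimum size, and the real size stays unknown: the limit of < 10% in this assay, at which 2 of the 4 values shown sit.

The compounds shown leave open whether the nitrogen's place in the ring matters, as pyridin-2-yl and pyridin-4-yl are not among them. They also leave open whether a phenyl ring carrying an amine or a carboxylic acid would keep the read-out of compound 1 or lose it as compound 4 does.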